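The source may report more compounds than this note shows. Statements on the series, on what has been measured and on what is new or still open speak of the compounds shown alone.

Compound 2 `N=C(NCCOCCO)N1C[C@H](O)[C@@H](O)[C@H](O)[C@H]1CO` is the member of the series carrying the 2-hydroxyethoxy group on the guanidine chain. In an assay on isolated protein for inhibition of alpha-galactosidase (Coffea arabica), read by spectrophotometry, with a stated time of 30 min (on this read-out lower numbers stand for stronger inhibition and higher numbers for weaker inhibition), compound 2 gives only a limit of > 1000000 nM, not a number. Compound 1 `CCCCNC(=N)N1C[C@H](O)[C@@H](O)[C@H](O)[C@H]1CO` carries a plain butyl chain in its place; in this assay compound 1 gives 18000 nM. Compound 3 `N=C(NCc1ccccc1)N1C[C@H](O)[C@@H](O)[C@H](O)[C@H]1CO` carries benzyl. In this assay compound 3 reaches only a limit of > 1000000 nM. Compound 2 thus sits at the limit of > 1000000 nM in this assay, at which 2 of the 3 values shown sit, as does compound 3, while compound 1 alone returns a number.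

The change to compound 4 `N=C(NCCCc1ccccc1)N1C[C@H](O)[C@@H](O)[C@H](O)[C@H]1CO` is benzyl in place of 2-hydroxyethoxy on a saturated chain carbon, two bonds along the chain from an amine nitrogen. The measured steps that bear on it are an at least 55-fold higher number from compound 1 to compound 2 (1.74 log units; beyond the scatter) and an at least 55-fold higher number from compound 1 to compound 3 (1.74 log units; beyond the scatter), both large losses from the butyl compound; the step that the two limits leave unreadable from compound 2 to compound 3 gives no reading. Compound 4 places the phenyl ring at the end of a chain comparable in length to that of compound 1, rather than directly on the carbon bound to the amine nitrogen as in compound 3. The step of an at least 25-fold lower number from compound 2 to compound 4 (1.39 log units; beyond the scatter) is therefore expected to run toward lower numbers, though with wide uncertainty. Compound 4 is estimated at 40000 nM, within 8000 nM to 600000 nM.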

Compound 4, half-maximal inhibitory concentration: > 1000000 nM
Compound 4: no number, only a limit; the forecaster's own chance of this, stated with the estimate: 30%; middle value at least 25-fold (1.39 log units) from the limit.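

Phenyl at the end of the chain does not preserve the inhibition seen with the butyl chain of compound 1: in this assay, the change gives an at least 55-fold higher number from compound 1 to compound 4 (1.74 log units; beyond the scatter). Compound 4 gives only a limit, > 1000000 nM, and not a number. The steps among compound 2, compound 3 and compound 4 cannot be read, so the compounds shown give no order among the hydroxyethoxy, benzyl and phenyl-ended chains, and moving the phenyl ring further along the chain brings no readable gain over compound 3, with compound 1 still the only compound that returns a number: the limit of > 1000000 nM in this assay, at which 3 of the 4 values shown sit.

Still open, on these data alone, is how closely the value of compound 1 is tied to the butyl chain itself, which a propyl chain, a pentyl chain or a longer chain of plain carbon would test. As far as these compounds go, it is also open whether a cyclohexyl ring in place of the phenyl, or an amine or a carboxylic acid at the chain end, would return a number in this assay.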